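Neopentyl to benzyl: what to expect of compound 4

The source may hold more compounds than are shown below. What is called first, only, known or untested is meant among the compounds shown, and "the series" means these compounds.

In an ADME assay on liver for metabolic stability, with Liver microsome (Homo sapiens) as the target, read by LC-MS, using microsomes (on this read-out higher numbers stand for fast clearance and lower numbers for slow clearance), compound 1 `CC(C)(C)[C@@H](O)C(=O)N1C[C@@H]2C[C@@H]2[C@H]1C(=O)NCc1cc(Cl)ccc1-n1cnnn1` gives < 15 mL.min-1.g-1, which is a limit of the assay and not a number. Compound 2 `O=C(NCc1cc(Cl)ccc1-n1cnnn1)[C@@H]1[C@H]2C[C@H]2CN1C(=O)[C@H](O)c1ccccc1` gives 61 mL.min-1.g-1. Compound 3 `CC(C)(C)C[C@@H](O)C(=O)N1C[C@@H]2C[C@@H]2[C@H]1C(=O)NCc1cc(Cl)ccc1-n1cnnn1` gives 20 mL.min-1.g-1, the lower of the two true numbers, and the gap between them runs a 3.1-fold lower number from compound 2 to compound 3 (0.48 log units; beyond the scatter). Against the limit, only a floor can be stated, an at least 1.3-fold higher number from compound 1 to compound 3 (0.12 log units; that floor lies within the scatter).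

Compound 4 `O=C(NCc1cc(Cl)ccc1-n1cnnn1)[C@@H]1[C@H]2C[C@H]2CN1C(=O)[C@H](O)Cc1ccccc1` differs from compound 3 by phenyl in place of tert-butyl on a saturated chain carbon, two bonds along the chain from a carbonyl carbon and an oxygen on a saturated carbon, which also reads as neopentyl to benzyl. The closest measured parallel is the same exchange on the saturated chain carbon bound to a carbonyl carbon and an oxygen, which runs an at least 4.0-fold higher number from compound 1 to compound 2 (0.60 log units; beyond the scatter). The gap between compound 2 and compound 3 points the same way, so a modest rise in this assay is expected, though the change here sits one bond further out. The expected step is a 2.8-fold higher number from compound 3 to compound 4 (0.44 log units; beyond the scatter). For compound 4 the estimated value is 55 mL.min-1.g-1, with an expected range of 25 mL.min-1.g-1 to 120 mL.min-1.g-1.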

Compound 4, intrinsic clearance in microsomes: 96 mL.min-1.g-1
For compound 4 the middle estimate is 1.7-fold (0.24 log units) below the measured one, within the range that was stated.
By their numbers in this assay, from the lowest: compound 3; then compounds 2 and 4 (each within the scatter of the next). At a limit, below all of these: compound 1.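

In this assay, for the compounds shown here, the exchange of tert-butyl for phenyl now has a true size one bond further out, a 4.8-fold higher number from compound 3 to compound 4 (0.68 log units; beyond the scatter), so the rise is no longer seen only on the saturated chain carbon bound to a carbonyl carbon and an oxygen: the same change on two cores in this assay, an at least 4.0-fold higher number (0.60 log units; beyond the scatter) from compound 1 to compound 2 and a 4.8-fold higher number (0.68 log units; beyond the scatter) from compound 3 to compound 4; the limit leaves it open whether they differ Benzyl and phenyl on that carbon cannot be told apart in this read-out, with a 1.6-fold higher number from compound 2 to compound 4 (0.20 log units; within the scatter). Compound 1 stands at a limit of the assay, < 15 mL.min-1.g-1, so against it only a floor can be read, an at least 6.4-fold higher number from compound 1 to compound 4 (0.80 log units; beyond the scatter).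

The compounds shown do not tell whether cyclohexyl in place of phenyl would read like tert-butyl or like phenyl. They also leave open whether a longer chain, such as phenethyl, would read as benzyl does.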